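Hydroxy to methoxy in a flat three-compound series

The source may hold more compounds than are shown below. What is called first, only, known or untested is meant among the compounds shown, and "the series" means these compounds.

In a functional assay on T47D cells (Homo sapiens) for antiproliferative activity, read by MTT assay, with a stated time of 48 h (on this read-out lower numbers stand for stronger inhibition and higher numbers for weaker inhibition), three compounds have been measured so far. Compound 1 `N#Cc1ncn(-c2ccc(F)cc2)c1/N=C/c1ccc([N+](=O)[O-])cc1` gives 15900 nM, compound 2 `COc1cc(/C=N/c2c(C#N)ncn2-c2ccc(F)cc2)ccc1O` gives 20100 nM and compound 3 `N#Cc1ncn(-c2ccc(F)cc2)c1/N=C/c1cc([N+](=O)[O-])ccc1O` gives 15300 nM. Compound 2 stands within the scatter of both of the others, so these numbers set no order among the three. For the measured compounds named here, no pair of measured compounds differs in one place only, so the size of a single change cannot be read directly from the data.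

Compound 4 `COc1ccc(/C=N/c2c(C#N)ncn2-c2ccc(F)cc2)cc1OC` differs from compound 2 by one change: methyl in place of hydrogen on an oxygen on an aromatic ring, that is, hydroxy to methoxy. No shift beyond the scatter is expected in this assay. This expectation rests on compound 2 at 20100 nM and compound 3 at 15300 nM, which carry different groups yet remain within the scatter of each other. The expected change is a 1.0-fold higher number from compound 2 to compound 4 (0.02 log units; within the scatter). For compound 4 the estimated value is 21000 nM, with an expected range of 10000 nM to 45000 nM.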

Compound 4, half-maximal inhibitory concentration: 7230 nM
The estimate for compound 4 lay 2.9-fold (0.46 log units) above the measured number, and the stated range ends above it.
By their numbers in this assay, from the lowest: compound 4; then compounds 3, 1 and 2 (each within the scatter of the next).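

In this assay the series now holds its first change in one place: methyl in place of hydrogen on an oxygen on an aromatic ring, hydroxy to methoxy, gives a 2.8-fold lower number from compound 2 to compound 4 (0.44 log units; beyond the scatter) and this modest step lies beyond the scatter. For the compounds shown here, this oxygen is thus a place where the read-out responds to a single small change, which the earlier compounds, none of them one change from another, could not show. Nothing at hand bears on why the number falls with this change.

Open, from the compounds shown here alone, is whether a longer chain on the same oxygen, such as ethoxy, would extend the step or reverse it, and whether an amine in place of the hydroxy would give a similar number. Also open, going by these compounds, is whether hydroxy to methoxy on compound 3 would give a step of similar size.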